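Replacing a hydroxy group with hydrogen on compound 1

The compounds below may be only part of what the source reports. "The series", "measured", "known", "first", "only" and "open" are said of these compounds alone.

Of the compounds shown here, two have numbers so far. In a functional assay, read by Griess assay, with a stated time of 2.5 h (a higher number here means a weaker inhibitor, a lower number a stronger inhibitor), compound 1 (`COc1cc(OC)c(OC)cc1/C=C/C(=O)c1ccc(O)cc1O`) gives 2.76 ug/mL and compound 2 (`COc1cc(OC)c(C(=O)/C=C/c2cc(OC)c(OC)cc2OC)c(OC)c1`) gives 1.98 ug/mL. These two values lie within the scatter of each other, so compound 1 has no distinct rank on the present numbers.

The next compound to be read is compound 3 (`COc1cc(OC)c(OC)cc1/C=C/C(=O)c1ccc(O)cc1`). Its structure departs from compound 1 in one place: hydrogen in place of hydroxy on an aromatic carbon. This is hydrogen in place of hydroxy on an aromatic carbon, ortho to a large group and meta to a hydroxy group, so that 2,4-dihydroxyphenyl becomes 4-hydroxyphenyl.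

Within the data shown here, no measured pair isolates this change, so the series offers no direct step as a guide. The estimate therefore stays anchored on compound 1 at 2.76 ug/mL, with a wide range. In this assay, no step beyond the scatter is expected, with a slight lean toward a higher number, meaning a weaker inhibitor. The expected step is a 1.2-fold higher number from compound 1 to compound 3 (0.09 log units; within the scatter). For compound 3 the estimated value is 3.4 ug/mL, with an expected range of 1.4 ug/mL to 8.5 ug/mL.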

Compound 3, half-maximal inhibitory concentration: 2.5 ug/mL
The estimate for compound 3 lay 1.4-fold (0.13 log units) above the measured number, and the stated range covers the measured number.
By their numbers in this assay, from the lowest: compounds 2, 3 and 1 (each within the scatter of the next).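

In this assay, among these compounds, the change from 2,4-dihydroxyphenyl to 4-hydroxyphenyl gives a 1.1-fold lower number from compound 1 to compound 3 (0.04 log units; within the scatter), the first direct reading of a single change. Among the compounds shown here, the hydroxy group ortho to a large group and meta to a hydroxy group can therefore be replaced by hydrogen without a step that this read-out separates from the scatter, so the series so far shows no dependence on that hydroxy group. No measured evidence on these compounds speaks to why this step is so small.

On these data alone, what an amine or a carboxylic acid would do at this same place remains open, since hydroxy and hydrogen alone cannot show whether the position responds to any replacement or is insensitive to substitution in general. Also open, as far as these compounds go, is the role of the remaining hydroxy group of the 4-hydroxyphenyl. No pair shown isolates a change there, and a single step within the scatter says nothing about how that group would behave if it were replaced.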